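Working notes: 3-methoxyphenyl to 4-methoxyphenyl on the carbonyl

This account rests on a few compounds, and the source may have more. Where it says the series, first, only, none or still open, it means among the compounds named here.

In a functional assay on MCF7 cells (Homo sapiens) for inhibition, read by MTT assay, with a stated time of 24 h (on this read-out higher numbers stand for weaker inhibition of growth and lower numbers for stronger inhibition of growth), compound 1 (`COc1ccc(C(=O)n2c(-c3cn(C)c4ccccc34)nc3ccccc32)cc1`) gives 16300 nM and compound 2 (`COc1cccc(C(=O)n2c(-c3cn(C)c4ccc(OC)cc34)nc3ccccc32)c1`) gives 14600 nM within the scatter of compound 1. Among the compounds with values here, compound 2 therefore stands level with the only other measured compound, and the two numbers set no order.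

The next compound, compound 3 (`COc1ccc(C(=O)n2c(-c3cn(C)c4ccc(OC)cc34)nc3ccccc32)cc1`), carries 4-methoxyphenyl in place of 3-methoxyphenyl on a carbonyl carbon and is otherwise the same as compound 2. The two have the same atoms, joined differently.

Within the data shown here, no measured pair differs in one place only, so the data do not show how large a single change can be. With compound 2 at 14600 nM as the anchor, no step beyond the scatter is expected in this assay for this swap. The expected step (a 1.0-fold lower number from compound 2 to compound 3 (0.02 log units; within the scatter)) is an estimate resting on that one anchor. Compound 3 is estimated at 14000 nM with an expected range from 6500 nM to 30000 nM for now.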

Compound 3, concentration for 50% growth inhibition: 14800 nM
Compound 3: middle estimate off by 1.1-fold (0.02 log units), on the low side, and the stated range covers the measured number.
By their numbers in this assay, from the lowest: compounds 2, 3 and 1 (each within the scatter of the next).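

The swap of 3-methoxyphenyl for 4-methoxyphenyl on a carbonyl carbon, read in this assay, gives the series its first one-place comparison (a 1.0-fold higher number from compound 2 to compound 3 (0.01 log units; within the scatter)), so at this position the two methoxyphenyl isomers cannot be told apart on this read-out. The second one-place pair concerns a different site: methoxy in place of hydrogen on an aromatic carbon (a 1.1-fold lower number from compound 1 to compound 3 (0.04 log units; within the scatter)) also stays within the scatter, so neither of the two single changes now available separates its compounds. Nothing on hand bears on why these steps are so small, and the size of the steps is all that can be stated here.

Both pairs keep to methoxy or hydrogen, so they leave open whether any change at these sites can give a step beyond the scatter, and the flat reading holds only for compounds 1, 2 and 3. Going by these compounds, it remains open whether an amine, a carboxylic acid or a longer alkoxy chain in place of the methoxy on the phenyl ring attached to the carbonyl would separate from these compounds in this assay.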